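Truncating the distal aryl to bromo on the benzyl arm

This account rests on a few compounds, and the source may have more. Where it says the series, first, only, none or still open, it means among the compounds named here.

Measured so far in an assay on isolated protein with Bile acid receptor (Homo sapiens) as the target; a lower number here means that less compound is needed, a higher number that more compound is needed for the effect:
compound 1 `COC(=O)/C=C/c1cccc(N(Cc2ccc(-c3ccc(F)c(F)c3)cc2)C(=O)C2CCCCC2)c1`: 72 nM
compound 2 `COC(=O)/C=C/c1cccc(N(Cc2ccc(-c3ccc(C(C)(C)C)cc3)cc2)C(=O)C2CCCCC2)c1`: 132 nM

On the numbers shown compound 2 stands next to compound 1; the step of a 1.8-fold higher number from compound 1 to compound 2 (0.26 log units; within the scatter) is within the scatter, so the two compounds are not separated by this assay. Compound 3 `COC(=O)/C=C/c1cccc(N(Cc2ccc(Br)cc2)C(=O)C2CCCCC2)c1` is not yet measured. It differs from compound 2 in one place: bromo in place of 4-(tert-butyl)phenyl on an aromatic carbon. For the measured compounds named here, the single measured step, a 1.8-fold higher number from compound 1 to compound 2 (0.26 log units; within the scatter), exchanges one aryl group for another at this position and keeps the attached ring; no measured step removes that ring altogether, so nothing in the present numbers bears directly on the change to compound 3. Since the two aryl variants gave numbers within the scatter of each other, the attached ring itself, rather than its substitution, is the untested element. A moderate rise in the number, beyond the scatter, is expected for compound 3. Compound 3 is estimated at 300 nM, with a range from 100 nM to 900 nM, which corresponds to an expected step of a 2.3-fold higher number from compound 2 to compound 3 (0.36 log units; beyond the scatter).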

Compound 3, half-maximal effective concentration: > 1000 nM
Compound 3: a limit, no number; the forecaster's own chance of this, stated with the estimate: 5%; middle value at least 3.3-fold (0.52 log units) away from the limit.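

In this assay, compound 3 carries a limit, not a number: the limit of > 1000 nM in this assay, at which 1 of the 3 values shown sits. Exchanging the aryl group for bromo gives an at least 7.5-fold higher number from compound 2 to compound 3 (0.87 log units; beyond the scatter) and, from the other aryl variant, an at least 13-fold higher number from compound 1 to compound 3 (1.14 log units; beyond the scatter); both steps lie beyond the scatter, whereas the exchange of one aryl group for the other, a 1.8-fold higher number from compound 1 to compound 2 (0.26 log units; within the scatter), does not. Across these compounds, then, keeping an aryl ring at this position matters more in this assay than the choice between 3,4-difluorophenyl and 4-(tert-butyl)phenyl, which the earlier pair could not show, although the limit leaves the full size of the loss unknown.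

The three compounds do not separate the need for an aromatic ring from the need for a group larger than bromo, so a cyclohexyl ring, a pyridyl ring or a butyl chain in the same place would be the informative comparison. Also open, from the compounds shown here alone, is whether the aryl dependence holds when other parts of the shared core change, for example with a carboxylic acid in place of the methyl ester.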